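The source may report more compounds than this note shows. Statements on the series, on what has been measured and on what is new or still open speak of the compounds shown alone.

The series is built around an amide that carries a nitrile on its double-bonded chain, and all of it was tested in a functional assay on BE(2)-C cells (Homo sapiens) for inhibition, read by MTT assay, with a stated time of 72 h; on this read-out higher numbers stand for weaker inhibition of growth and lower numbers for stronger inhibition of growth. Compound 1 `COc1ccc(CNC(=O)/C(C#N)=C/c2ccc[nH]2)cc1` gives 47000 nM in this assay. Compound 3 `COc1ccc(CNC(=O)/C(C#N)=C/c2ccco2)cc1` gives 24000 nM in this assay. Compound 2 `N#C/C(=C\c1ccc[nH]1)C(=O)NCc1ccc(Cl)c(Cl)c1` gives 43000 nM in this assay, which places it second highest of the three numbers; compound 1 lies nearest to it and compound 3 furthest, and both gaps fall within the scatter, so no order among the three can be claimed.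

Compound 4 `N#C/C(=C\c1ccco1)C(=O)NCc1ccc(Cl)c(Cl)c1` has not yet been measured. It differs from compound 2 by one change: furan-2-yl in place of 1H-pyrrol-2-yl on a double-bonded chain carbon bound to a double-bonded chain carbon. The same exchange has been made once among the measured compounds, from compound 1 to compound 3, where it gave a 2.0-fold lower number from compound 1 to compound 3 (0.29 log units; within the scatter). Among the compounds with values here, that single step is the only guide, and it stayed within the scatter. Compound 4 is therefore expected to show a step of about a 2.0-fold lower number from compound 2 to compound 4 (0.29 log units; within the scatter), a slight drift toward a lower number rather than any movement beyond the scatter. On that basis compound 4 is estimated at 22000 nM in this assay, with a range from 8000 nM to 60000 nM.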

Compound 4, concentration for 50% growth inhibition: > 50000 nM
Compound 4: a limit, no number; the forecaster's own chance of this, stated with the estimate: 5%; at least 2.2-fold (0.35 log units) between middle value and limit.
By their numbers in this assay, from the lowest: compounds 3, 2 and 1 (each within the scatter of the next). At a limit, above all of these: compound 4.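

In this assay compound 4 gives > 50000 nM, which is a limit of the assay and not a number. The exchange of 1H-pyrrol-2-yl for furan-2-yl on a double-bonded chain carbon bound to a double-bonded chain carbon now reads as an at least 1.1-fold higher number from compound 2 to compound 4 (0.06 log units; that floor lies within the scatter), so on the core of compound 2 this change does not repeat the drift toward a lower number that the earlier pair suggested, although the floor of the step stays within the scatter. What the earlier compounds could not show is that a single reading of this change does not settle its size or direction on another core, and the comparison now stands as follows: the same change on two cores in this assay, a 2.0-fold lower number (0.29 log units; within the scatter) from compound 1 to compound 3 and an at least 1.1-fold higher number (0.06 log units; that floor lies within the scatter) from compound 2 to compound 4; the limit leaves it open whether they differ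

The compounds shown leave open how far the value of compound 4 lies past its limit, and with it whether the change truly behaves differently on the two cores. They also leave open how a carboxylic acid or an amine would read in place of the furan-2-yl or 1H-pyrrol-2-yl group on this carbon.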